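This account rests on a few compounds, and the source may have more. Where it says the series, first, only, none or still open, it means among the compounds named here.

Series notes, sulfonyl variation on a shared core.

Compound 1 `COc1ccc(NS(=O)(=O)c2ccc3c(c2)C(n2ccccc2=O)=CC(C)(C)O3)cc1` and compound 2 `CN(C)S(=O)(=O)c1ccc2c(c1)C(n1ccccc1=O)=CC(C)(C)O2` differ only in the group on the sulfonyl sulfur. In a functional assay on the whole organism (aorta) with Rattus norvegicus as the target (a higher number here means a larger maximal response, a lower number a smaller maximal response), compound 1 gives 77.9%, and compound 2 gives 78.3%. The step of a number 0.4 percentage points higher from compound 1 to compound 2 (within the scatter) shows that exchanging the (4-methoxyphenyl)amino for dimethylamino leaves the maximal response essentially where it was. Within the data shown here, compound 2 holds the higher of the two numbers so far, but with compound 1 so close the two cannot be told apart.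

The next compound, compound 3 `CC1(C)C=C(n2ccccc2=O)c2cc(S(=O)(=O)N3CCOCC3)ccc2O1`, is taken from compound 2 by the change (morpholin-4-yl in place of dimethylamino on a sulfonyl sulfur). Among the measured compounds shown here, the only step measured at this position, the one from compound 1 to compound 2, was within the scatter, so the sulfonyl substituent has not so far moved the read-out in this assay. A ring of the entering kind has not been tested here. On that basis the step of a number 0.3 percentage points lower from compound 2 to compound 3 (within the scatter) is expected to stay within the scatter, with no clear direction. For compound 3 the estimated value in this assay is 78%, within a range from 66% to 90%.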

Compound 3, largest response reached (Emax), in percent of the reference or control that the assay uses: 75.5%
Estimate against measurement, compound 3: 2.5 percentage points above; measured number inside the range.
By their numbers in this assay, from the lowest: compounds 3, 1 and 2 (each within the scatter of the next).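

Among these compounds, with morpholin-4-yl, a ring stands on the sulfonyl sulfur for the first time, and this assay shows a number 2.8 percentage points lower from compound 2 to compound 3 (within the scatter) for the exchange of dimethylamino. Against the secondary sulfonamide, the exchange of (4-methoxyphenyl)amino for the same ring gives a number 2.4 percentage points lower from compound 1 to compound 3 (within the scatter) and likewise stays inside the usual spread of repeated measurements. An open-chain dimethylamino, an aromatic (4-methoxyphenyl)amino and the six-membered morpholin-4-yl therefore cannot be told apart by largest response at this position, and no measurement on hand accounts for this.

Going by these compounds, whether this holds for every group on the sulfonyl sulfur remains open: a plain amino group, a piperazine ring with its free amine, or a longer chain ending in a carboxylic acid could still separate from these three compounds. The compounds shown also leave open whether the read-out would hold with a carbonyl in place of the sulfonyl, as all three carry the sulfonyl on the shared core.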